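The source may hold more compounds than are shown below. What is called first, only, known or untested is meant among the compounds shown, and "the series" means these compounds.

Measured so far in a functional assay on HepG2 cells (Homo sapiens) for inhibition, read by MTT assay, with a stated time of 48 h; on this read-out higher numbers stand for weaker inhibition and lower numbers for stronger inhibition:
Compound 1 `O=C(Nc1cnn(-c2ccccc2)c1)c1cccc(NS(=O)(=O)c2ccccc2)c1` — compound 1 gives 10100 nM.
Compound 2 `Cc1ccc(-n2cc(NC(=O)c3cccc(NS(=O)(=O)c4ccc(Cl)cc4)c3)cn2)cc1` — compound 2 gives 2440 nM.
Compound 3 `Cn1cc(NC(=O)c2ccc(NS(=O)(=O)c3ccccc3)cc2)cn1` — compound 3 gives only > 100000 nM, which is a limit of this assay and not a number.

Compound 3 therefore stands at the weak end of what is shown: its value is one of those at the limit of > 100000 nM in this assay, at which 1 of the 3 values shown sits, and no number for it exists, only the statement that inhibition was not reached within the measured range. Compound 1 and compound 2 both carry an aryl group on the ring nitrogen and give numbers; compound 3 carries a methyl there and gives none.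

Compound 4 `Cc1ccc(-n2cc(NC(=O)c3ccc(NS(=O)(=O)c4ccccc4)cc3)cn2)cc1` has not been measured in this assay. It differs from compound 3 in one place: 4-methylphenyl in place of methyl on an aromatic nitrogen. Compound 4 thus shares with compound 1 and compound 2 an aryl group on that nitrogen, while keeping the rest of compound 3 unchanged. No measured step of this kind exists among the compounds shown, so the direction rests on the observation that the two compounds with an aryl group on that nitrogen, compound 1 at 10100 nM and compound 2 at 2440 nM, return numbers. The step from compound 3 to compound 4 is expected to move toward stronger inhibition, by an at least 3.3-fold lower number from compound 3 to compound 4 (0.52 log units; beyond the scatter), beyond the scatter but uncertain, since compound 3 gives only a limit as its starting point. Compound 4 is estimated at 30000 nM, within 5000 nM to 150000 nM, with a real chance that this assay again reports only a limit.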

Compound 4, half-maximal inhibitory concentration: 18100 nM
Compound 4: middle estimate off by 1.7-fold (0.22 log units), on the high side; low and high end bracket the measured number.
By their numbers in this assay, from the lowest: compound 2; then compounds 1 and 4 (each within the scatter of the next). At a limit, above all of these: compound 3.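

In this assay, within the data shown here, 4-methylphenyl in place of methyl on an aromatic nitrogen gives an at least 5.5-fold lower number from compound 3 to compound 4 (0.74 log units; beyond the scatter) with the rest of the structure unchanged, the first step at this position that can be read on its own. Among these compounds, none of the earlier compounds formed a pair differing only here, so the link between an aryl group on this nitrogen and a measurable number was until now only suggested, and compound 4 now gives 18100 nM on the core of compound 3. Compound 3 remains a limit and not a number, so the step has a lower bound and no exact size: the limit of > 100000 nM in this assay, at which 1 of the 4 values shown sits.

As far as these compounds go, only one replacement at this nitrogen can be read, so it stays open whether the ring itself, its 4-methyl group or simply the larger size of the group goes with the change, which a benzyl group, a cyclohexyl ring or a longer chain such as n-butyl in the same place would help to separate. Also open, from the compounds shown here alone, is whether the same step holds on the cores of compound 1 and compound 2, or with an amine or a carboxylic acid on the new ring.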